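Bromo for Fluoro on the Anilino Ring of Compound 3

A few compounds are considered here, and "the series" means these few. Any claim that something is new, unique, unknown or untested is made for them only; others in the source may bear on it.

Measured in a functional assay on NCI-H1975 cells (Homo sapiens) for antiproliferative activity, read by MTT assay, with a stated time of 72 h; on this read-out higher numbers stand for weaker inhibition and lower numbers for stronger inhibition:
compound 1 `COc1cc2ncnc(Nc3ccc(Cl)c(C(F)(F)F)c3)c2cc1OCCCCC(=O)Nc1ccc(S(N)(=O)=O)cc1` gives 3220 nM
compound 2 `COc1cc2ncnc(Nc3cccc(Br)c3)c2cc1OCCCCC(=O)Nc1ccc(S(N)(=O)=O)cc1` gives 11400 nM
compound 3 `COc1cc2ncnc(Nc3ccc(F)cc3)c2cc1OCCCCC(=O)Nc1ccc(S(N)(=O)=O)cc1` gives > 40000 nM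

Compound 3 sits at the assay limit (the limit of > 40000 nM in this assay, at which 1 of the 3 values shown sits), so only a limit and no number is known for it, and it is the weakest of the three. Compound 4 `COc1cc2ncnc(Nc3ccc(Br)cc3)c2cc1OCCCCC(=O)Nc1ccc(S(N)(=O)=O)cc1` differs from it only by bromo in place of fluoro on an aromatic carbon. Going by the values given here, no measured step swaps this halogen alone. The nearest steps are an at least 12-fold higher number from compound 1 to compound 3 (1.09 log units; beyond the scatter) and an at least 3.5-fold higher number from compound 2 to compound 3 (0.54 log units; beyond the scatter), which both show the 4-fluorophenyl giving the highest number of the set, whereas compound 1 and compound 2, with their other halogenated anilines, sit clear of the limit. A bromo in this position is therefore expected to bring compound 4 back under the limit, by a step of an at least 2.0-fold lower number from compound 3 to compound 4 (0.30 log units; that floor lies within the scatter). For compound 4 the expected value is 20000 nM, within 6000 nM to 60000 nM.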

Compound 4, half-maximal inhibitory concentration: 23300 nM
Beside the measured number, compound 4's estimate is 1.2-fold (0.07 log units) below it; the range from low to high includes it.
By their numbers in this assay, from the lowest: compound 1; then compound 2; then compound 4. At a limit, above all of these: compound 3.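

With bromo in place of fluoro, compound 4 gives a number in this assay, while compound 3 remains at a limit: the limit of > 40000 nM in this assay, at which 1 of the 4 values shown sits. On these data alone, the swap itself reads as an at least 1.7-fold lower number from compound 3 to compound 4 (0.23 log units; that floor lies within the scatter), so its true size stays unknown. Among the bromo compounds, 4-bromophenyl in place of 3-bromophenyl gives a 2.0-fold higher number from compound 2 to compound 4 (0.31 log units; beyond the scatter), the first sign that the place of the bromo counts, while a 7.2-fold higher number from compound 1 to compound 4 (0.86 log units; beyond the scatter) leaves the 4-chloro-3-(trifluoromethyl)phenyl of compound 1 ahead. The compounds shown leave open how a chloro or a nitrile in this same place would read in this assay.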